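A few compounds are considered here, and "the series" means these few. Any claim that something is new, unique, unknown or untested is made for them only; others in the source may bear on it.

Working notes on the series. Three compounds share one core and differ only in the group on the aromatic carbon of the fused ring. Compound 1 `CN(C(=O)c1c(O)c2c(C(F)(F)F)cccc2n(C)c1=O)c1ccccc1` carries trifluoromethyl and in a functional assay on the whole organism for inhibition, with Mus musculus as the target, at a dose of 1 mg/kg by the oral route (on this read-out higher numbers stand for more inhibition at the one dose given (going by the name of the read-out) and lower numbers for less inhibition), compound 1 gives 99%. Compound 2 `CSc1cccc2c1c(O)c(C(=O)N(C)c1ccccc1)c(=O)n2C` carries methylsulfanyl, and compound 2 gives 100%. Compound 3 `CN(C(=O)c1c(O)c2c([N+](=O)[O-])cccc2n(C)c1=O)c1ccccc1` carries nitro, and compound 3 gives 96%. Compound 3 holds the lowest of the three numbers, but every step among them sits within the scatter: a number 1 percentage points higher from compound 1 to compound 2 (within the scatter), a number 3 percentage points lower from compound 1 to compound 3 (within the scatter) and a number 4 percentage points lower from compound 2 to compound 3 (within the scatter). Across these three groups the read-out is effectively flat at the dose given.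

Compound 4 `CN(C)c1cccc2c1c(O)c(C(=O)N(C)c1ccccc1)c(=O)n2C` is not yet measured. It differs from compound 3 as follows: dimethylamino in place of nitro on an aromatic carbon. Within the data shown here, no measured step exchanges nitro for dimethylamino, so the bearing steps are only the three above, all within the scatter, which gives no basis to expect a move beyond the scatter. For compound 4 the expected step is a number 1 percentage points lower from compound 3 to compound 4 (within the scatter). Compound 4 is estimated at 95%, within a range of 78% to 100%, the lower end allowing that an untested group may fall off.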

Compound 4, a percentage reported as inhibition, in the whole organism at one dose (the size of the read-out at that dose, not a potency): 93%
Estimate against measurement, compound 4: 2 percentage points above, and the stated range covers the measured number.
By their numbers in this assay, from the lowest: compounds 4, 3, 1 and 2 (each within the scatter of the next).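

Dimethylamino extends the flat picture on this aromatic carbon to a fourth group: in this assay the steps read a number 3 percentage points lower from compound 3 to compound 4 (within the scatter) and a number 6 percentage points lower from compound 1 to compound 4 (within the scatter) and a number 7 percentage points lower from compound 2 to compound 4 (within the scatter) and none of them separates the groups. The exchange for nitro is the most telling one here, since it replaces a group with 2 hydrogen-bond acceptors and a double bond outside aromatic rings by one with 1 hydrogen-bond acceptor and no such double bond, and the read-out still stays within the scatter. Nothing measured on these compounds explains why the read-out holds across this change.

On these data alone, whether a carboxylic acid, an unsubstituted amine or a longer alkyl chain on this carbon would hold as well remains open. So does whether these four compounds would separate at a lower dose, as the single dose gives no potency.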